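This account rests on a few compounds, and the source may have more. Where it says the series, first, only, none or still open, it means among the compounds named here.

For the measured compounds named here, compound 1 `O=C1CSC(c2cccc(Cl)c2)N1CCN1CCCCC1` is one of three compounds measured in an ADME assay on Vero cells (Chlorocebus sabaeus) for cytotoxicity, read by neutral red uptake, tested at 1575 ug/mL; a higher number here means a weaker effect of the compound at the concentration tested, a lower number a stronger effect. Compound 1 gives 20%, the second highest of the three numbers. Compound 3 `O=C1CSC(c2ccccc2[N+](=O)[O-])N1CCN1CCCCC1` gives 24%, and compound 2 `O=C1CSC(c2ccc(O)cc2)N1CCN1CCCCC1` gives 12%; both sit within the scatter of compound 1. Compound 4 `O=C1CSC(c2ccc(F)cc2)N1CCN1CCCCC1` has not yet been measured; it differs from compound 1 in one place: 4-fluorophenyl in place of 3-chlorophenyl on a saturated ring carbon. Going by the values given here, the only measured step that changes the group on a saturated ring carbon, a number 8 percentage points lower from compound 1 to compound 2 (within the scatter), stays within the scatter, and no measured step exchanges one halogen for another. The change is therefore expected to bring a number 2 percentage points lower from compound 1 to compound 4 (within the scatter), nothing beyond the scatter. Compound 4 is estimated to give 18% in this assay, with a range from 8% to 30%.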

Compound 4, a percentage reported as activity, at one concentration (the size of the read-out at that concentration, not a potency): 14%
For compound 4 the middle estimate is 4 percentage points above the measured one; the measured number falls inside the stated range.
By their numbers in this assay, from the lowest: compounds 2, 4, 1 and 3 (each within the scatter of the next, the first and the last beyond it).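

In this assay, 4-fluorophenyl in place of 3-chlorophenyl on the saturated ring carbon brings a number 6 percentage points lower from compound 1 to compound 4 (within the scatter), so this position now holds a second halogen-bearing phenyl group without a change beyond the scatter. Fluoro in place of hydroxy on an aromatic carbon brings a number 2 percentage points higher from compound 2 to compound 4 (within the scatter), so these two groups cannot be told apart here. Nothing available explains either step.

From the compounds shown here alone, whether an amine or a carboxylic acid on the phenyl ring would shift the number beyond the scatter stays open. So does the effect of replacing the phenyl ring with a longer alkyl chain.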